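This account rests on a few compounds, and the source may have more. Where it says the series, first, only, none or still open, it means among the compounds named here.

Compound 1 `CC(C)c1cccc(NC(=O)CCc2cccc3c2B(O)OC3)c1`: 510 nM
Compound 2 `O=C(CCc1cccc2c1B(O)OC2)Nc1cccc(-c2ccc(F)cc2)c1`: 93 nM
Compound 3 `O=C(CCc1cccc2c1B(O)OC2)Nc1cccc(-c2ccc(Cl)cc2)c1`: 220 nM

All three share one core and differ only in the group carried on an aromatic carbon. In a functional assay on SK-OV-3 cells (Homo sapiens) for antiproliferative activity, read by MTT assay, with a stated time of 72 h (on this read-out lower numbers stand for stronger inhibition and higher numbers for weaker inhibition), compound 3 stands second highest of the three numbers: its neighbours are a 2.3-fold lower number from compound 1 to compound 3 (0.37 log units; beyond the scatter) and a 2.4-fold higher number from compound 2 to compound 3 (0.37 log units; beyond the scatter). Compound 4 `N#Cc1ccc(-c2cccc(NC(=O)CCc3cccc4c3B(O)OC4)c2)cc1` takes the next step, (cyano in place of chloro on an aromatic carbon). For the measured compounds named here, no measured step exchanges a halogen for cyano on that carbon; the only exchange on the same aromatic carbon is a 2.4-fold higher number from compound 2 to compound 3 (0.37 log units; beyond the scatter), a modest change. A step of similar modest size in either direction, or none beyond the scatter, is therefore expected for a 1.4-fold lower number from compound 3 to compound 4 (0.14 log units; within the scatter). Compound 4 is estimated at 160 nM, within a range of 60 nM to 450 nM.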

Compound 4, half-maximal inhibitory concentration: 340 nM
Beside the measured number, compound 4's estimate is 2.1-fold (0.33 log units) below it; the measured number falls inside the stated range.
By their numbers in this assay, from the lowest: compound 2; then compounds 3, 4 and 1 (each within the scatter of the next, the first and the last beyond it).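

Exchanging chloro for cyano on this carbon moves the number only within the scatter (a 1.5-fold higher number from compound 3 to compound 4 (0.19 log units; within the scatter)), so these two groups cannot be told apart here. The fluoro compound stays clearly apart from the cyano compound (a 3.7-fold higher number from compound 2 to compound 4 (0.56 log units; beyond the scatter)), and, unlike the fluoro and chloro compounds, the cyano compound cannot be told apart from the isopropyl compound (a 1.5-fold lower number from compound 1 to compound 4 (0.18 log units; within the scatter)). No measurement offered here explains these differences.

The compounds shown leave open what an amine, a carboxylic acid or a methoxy group would give on this carbon of the outer ring.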